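Isobutyl in place of 2,6-dichlorophenyl on a carbonyl carbon

The source may report more compounds than this note shows. Statements on the series, on what has been measured and on what is new or still open speak of the compounds shown alone.

compound 1 `CN1CCN(c2cccc(N/C=C3\C(=O)Nc4ccc(NC(=O)c5cccc(F)c5)cc43)c2)CC1` gives 6720 nM
compound 2 `CN1CCN(c2cccc(N/C=C3\C(=O)Nc4ccc(NC(=O)c5c(Cl)cccc5Cl)cc43)c2)CC1` gives 2370 nM
compound 3 `CC(C)CC(=O)Nc1ccc2c(c1)/C(=C/Nc1cccc(N3CCN(C)CC3)c1)C(=O)N2` is not yet measured

Among the compounds with values here, in a functional assay on HepG2 cells (Homo sapiens) for inhibition, read by sulforhodamine B assay, with a stated time of 3 days (a higher number here means a weaker inhibitor, a lower number a stronger inhibitor), compound 2 gives 2370 nM, the lowest of the two numbers so far. Compound 3 keeps the shared core but changes one group: isobutyl in place of 2,6-dichlorophenyl on a carbonyl carbon. Within the data shown here, one measured step bears on this: a 2.8-fold lower number from compound 1 to compound 2 (0.45 log units; beyond the scatter), which exchanged 3-fluorophenyl for 2,6-dichlorophenyl on the same carbonyl carbon. Among the measured compounds shown here, both of those groups contain a ring, and no measured compound has a group without one, so the guidance is weak. Since compound 1 at 6720 nM shows that leaving 2,6-dichlorophenyl can raise the number, a modest rise is expected, the estimated step being a 2.1-fold higher number from compound 2 to compound 3 (0.32 log units; beyond the scatter). Compound 3 is expected at 5000 nM, within an estimated range from 1500 nM to 15000 nM.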

Compound 3, half-maximal inhibitory concentration: 5070 nM
Compound 3: middle estimate off by 1.0-fold (0.01 log units), on the low side; the measured number falls inside the stated range.
By their numbers in this assay, from the lowest: compound 2; then compounds 3 and 1 (each within the scatter of the next).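

In this assay, a group with no ring can now be read at this carbonyl carbon: putting isobutyl in place of 2,6-dichlorophenyl gives a 2.1-fold higher number from compound 2 to compound 3 (0.33 log units; beyond the scatter). Putting isobutyl in place of 3-fluorophenyl gives a 1.3-fold lower number from compound 1 to compound 3 (0.12 log units; within the scatter), so having a ring at this position does not by itself separate these groups, and only 2,6-dichlorophenyl stands apart, with the lowest number of the three. Nothing available here explains why that group differs from the other two.

Still open, as far as these compounds go, is whether a longer chain, an amine or a carboxylic acid on this carbonyl carbon would give a number closer to that of compound 2 or to those of compounds 1 and 3. Also open, from the compounds shown here alone, is how a phenyl carrying a single chlorine would compare with 2,6-dichlorophenyl.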